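Aryl sulfonamide swap on a shared indazole-bearing core

A few compounds are considered here, and "the series" means these few. Any claim that something is new, unique, unknown or untested is made for them only; others in the source may bear on it.

Measured so far in a functional assay on HCT-116 cells (Homo sapiens) for antiproliferative activity, read by MTT assay, with a stated time of 72 h; on this read-out higher numbers stand for weaker inhibition and lower numbers for stronger inhibition:
- compound 1, `CC(=O)N(C)c1ccc2[nH]c(-c3n[nH]c4ccccc34)cc2n1`, gives 14800 nM
- compound 2, `CN(c1ccc2[nH]c(-c3n[nH]c4ccccc34)cc2n1)S(=O)(=O)c1ccc(Br)cc1`, gives 9850 nM
- compound 3, `COc1ccc(S(=O)(=O)N(C)c2ccc3[nH]c(-c4n[nH]c5ccccc45)cc3n2)cc1`, gives 22400 nM

Compound 3 stands at the highest of the three numbers in this assay. Its nearest neighbour is compound 1, which lies within the scatter of it, while the other measured step, a 2.3-fold higher number from compound 2 to compound 3 (0.36 log units; beyond the scatter), is a modest one beyond the scatter.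

Compound 4, `CN(c1ccc2[nH]c(-c3n[nH]c4ccccc34)cc2n1)S(=O)(=O)c1cccc([N+](=O)[O-])c1`, differs from compound 3 by 3-nitrophenyl in place of 4-methoxyphenyl on a sulfonyl sulfur. Within the data shown here, of the measured steps, only the one from compound 2 to compound 3 bears on this change, since it also swaps the substituent on the aryl ring of the sulfonyl group, and it was a 2.3-fold higher number from compound 2 to compound 3 (0.36 log units; beyond the scatter). The step from compound 1 to compound 2, a 1.5-fold lower number from compound 1 to compound 2 (0.18 log units; within the scatter), shows that the acyl or sulfonyl group on the nitrogen matters little here. Replacing the methoxy-bearing ring by a nitro-bearing ring is therefore expected to move the number back toward compound 2, by a 1.9-fold lower number from compound 3 to compound 4 (0.27 log units; within the scatter). Compound 4 is estimated at 12000 nM, within a range from 5000 nM to 30000 nM.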

Compound 4, half-maximal inhibitory concentration: 13600 nM
Estimate against measurement, compound 4: 1.1-fold (0.05 log units) below; the range from low to high includes it.
By their numbers in this assay, from the lowest: compounds 2, 4, 1 and 3 (each within the scatter of the next, the first and the last beyond it).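

In this assay, the sulfonyl sulfur accepted 3-nitrophenyl without a shift beyond the scatter from either aryl group already in place there (a 1.6-fold lower number from compound 3 to compound 4 (0.22 log units; within the scatter) and a 1.4-fold higher number from compound 2 to compound 4 (0.14 log units; within the scatter)). Among these compounds, the earlier compounds offered only one aryl swap, from 4-bromophenyl to 4-methoxyphenyl, and that modest step beyond the scatter now stands as the only such gap among the sulfonamides, with compound 4 within the scatter of both partners. All three aryl sulfonamides therefore remain in a narrow band of weak inhibition, and the nitro group and its ring position change together, so neither can be read alone.

From the compounds shown here alone, it remains open whether an amine or a carboxylic acid on this aryl ring, or a longer chain on the sulfonamide nitrogen, would shift the number further. Nothing available here explains the small differences among these aryl groups.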